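This account rests on a few compounds, and the source may have more. Where it says the series, first, only, none or still open, it means among the compounds named here.

Compound 1 `CCCCc1cn(C[C@H](O)[C@H]2OC(=O)C(OCc3ccccc3)=C2OCc2ccccc2)nn1`: 26300 nM
Compound 2 `O=C1O/C(=C\Cn2cc(-c3cc(C(F)(F)F)cc(C(F)(F)F)c3)nn2)C(OCc2ccccc2)=C1OCc1ccccc1`: > 100000 nM

Within the data shown here, in an ADME assay on HFF cells (Homo sapiens) for cytotoxicity, read by MTT assay, with a stated time of 72 h (a higher number here means a weaker inhibitor, a lower number a stronger inhibitor), compound 1 gives 26300 nM, the only plain number among the two values shown. Compound 2 reaches only a limit in this assay, > 100000 nM, and the standing of compound 1 is therefore read against (the limit of > 100000 nM in this assay, at which 1 of the 2 values shown sits).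

Compound 3 `O=C1O[C@H]([C@@H](O)Cn2cc(CNS(=O)(=O)c3ccc(F)cc3)nn2)C(OCc2ccccc2)=C1OCc1ccccc1` differs from compound 1 by ((4-fluorophenyl)sulfonyl)amino in place of propyl on a saturated chain carbon bound to an aromatic carbon. Among the measured compounds shown here, no measured step of this kind is available, so any expectation rests on compound 1 alone. A step toward weaker inhibition is expected from compound 1 to compound 3, of about a 1.7-fold higher number from compound 1 to compound 3 (0.23 log units; within the scatter), modest and close to the scatter. For compound 3 the estimate is 45000 nM, between 15000 nM and 100000 nM, with a fair chance that this assay returns only a limit.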

Compound 3, half-maximal inhibitory concentration: 30 nM
Beside the measured number, compound 3's estimate is 1500-fold (3.18 log units) above it, and the stated range ends above it.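

In this assay, replacing propyl with ((4-fluorophenyl)sulfonyl)amino gives an 880-fold lower number from compound 1 to compound 3 (2.94 log units; beyond the scatter). The reading on the shared core therefore depends strongly on what sits on this saturated chain carbon bound to an aromatic carbon. Nothing shown accounts for the size of this step.

The compounds shown leave open which part of the entering group carries the step, with the sulfonyl, the amino and the 4-fluorophenyl entering together. They also leave open how an amine, a carboxylic acid or a longer chain would read at this place.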